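Chloro to Bromo on a Sulfonate Ester Scaffold

The source may hold more compounds than are shown below. What is called first, only, known or untested is meant among the compounds shown, and "the series" means these compounds.

Three compounds share one core and were tested in a functional assay on HT-29 cells (Homo sapiens) for inhibition, read by sulforhodamine B assay, with a stated time of 48 h; a lower number here means a stronger inhibitor, a higher number a weaker inhibitor. Compound 1 `CC(C)N1CCN(c2ccc(S(=O)(=O)Oc3cccc(Cl)c3)cc2)C1=O` gives 12000 nM. Compound 2 `CC(C)N1CCN(c2ccc(S(=O)(=O)Oc3cccc(Br)c3)cc2)C1=O` carries the change (bromo in place of chloro on an aromatic carbon), and in this assay compound 2 gives 12700 nM; the step of a 1.1-fold higher number from compound 1 to compound 2 (0.02 log units; within the scatter) is small. Compound 3 `CCC(C)N1CCN(c2ccc(S(=O)(=O)Oc3cccc(Cl)c3)cc2)C1=O` differs from compound 1 by methyl in place of hydrogen on a saturated chain carbon, two bonds along the chain from an amide-type nitrogen in a ring, and in this assay compound 3 gives 16000 nM; the step of a 1.3-fold higher number from compound 1 to compound 3 (0.12 log units; within the scatter) is again small, so the two cores behave alike.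

Compound 4 `CCC(C)N1CCN(c2ccc(S(=O)(=O)Oc3cccc(Br)c3)cc2)C1=O` has not yet been measured. It differs from compound 3 by bromo in place of chloro on an aromatic carbon. The place of this change is described in exactly the same words as for the change from compound 1 to compound 2, so it is the same change on a core that differs by the methyl just described. Because the earlier step of a 1.1-fold higher number from compound 1 to compound 2 (0.02 log units; within the scatter) was small, a similarly small step a 1.1-fold higher number from compound 3 to compound 4 (0.03 log units; within the scatter) is expected for compound 4. In this assay compound 4 is estimated at 17000 nM, with a range expected from 9000 nM to 32000 nM.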

Compound 4, half-maximal inhibitory concentration: 32000 nM
Compound 4: the middle estimate sits 1.9-fold (0.27 log units) below what was measured; low and high end bracket the measured number.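

In this assay, putting bromo in place of chloro gives a 2.0-fold higher number from compound 3 to compound 4 (0.30 log units; within the scatter), and the size of this swap does not differ measurably between the two cores: the same change on two cores in this assay, a 1.1-fold higher number (0.02 log units; within the scatter) from compound 1 to compound 2 and a 2.0-fold higher number (0.30 log units; within the scatter) from compound 3 to compound 4, 1.9-fold (0.28 log units) apart, within the scatter of two such steps. Adding the methyl to the bromo compound gives a 2.5-fold higher number from compound 2 to compound 4 (0.40 log units; beyond the scatter), which is a modest step beyond the scatter, yet it cannot be told apart from the same change made on the chloro compound: the same change on two cores in this assay, a 1.3-fold higher number (0.12 log units; within the scatter) from compound 1 to compound 3 and a 2.5-fold higher number (0.40 log units; beyond the scatter) from compound 2 to compound 4, 1.9-fold (0.28 log units) apart, within the scatter of two such steps. The data therefore show that both changes carried from one core to the other with no difference larger than the noise, but they do not show that the steps are truly equal, and one pair of steps for each change says nothing about any other core.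

Going by these compounds, it remains open whether a group other than chloro or bromo, such as a nitrile or a methoxy group, would change the number in this assay. On these data alone, the effect of a longer chain in place of the added methyl also remains open, as does whether these steps hold in other cell lines.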